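This account rests on a few compounds, and the source may have more. Where it says the series, first, only, none or still open, it means among the compounds named here.

Measured in a functional assay on cells (T-cell, Mus musculus, strain BALB/c) for inhibition, read by MTT assay, with a stated time of 72 h; a lower number here means a stronger inhibitor, a higher number a weaker inhibitor:
Compound 1 `COC(=O)c1c(F)cccc1OC(=O)COc1cc(O)c2c(=O)cc(-c3ccccc3)oc2c1`: 40300 nM
Compound 2 `C=C(CCc1cc(O)c2c(=O)cc(-c3ccccc3)oc2c1)Cc1c(Br)cccc1C(=O)CC`: 40700 nM
Compound 3 `COC(=O)c1c(Br)cccc1OC(=O)COc1cc(O)c2c(=O)cc(-c3ccccc3)oc2c1`: 41700 nM

Compound 3 gives the highest of the three numbers in this assay, yet its distance to compound 2 and to compound 1 is within the scatter in each case, so the three compounds cannot be separated on these data. The unmeasured compound 4 `COC(=O)c1ccc(Br)cc1OC(=O)COc1cc(O)c2c(=O)cc(-c3ccccc3)oc2c1` keeps the same atoms as compound 3 and differs only in how they are joined: a group of 11 heavy atoms (8 carbon, 2 oxygen, 1 bromine; one six-membered aromatic ring of carbon only) in place of a group of 11 heavy atoms (8 carbon, 2 oxygen, 1 bromine; one six-membered aromatic ring of carbon only), on an oxygen next to a carbonyl group. Going by the values given here, the only step measured so far, a 1.0-fold higher number from compound 1 to compound 3 (0.01 log units; within the scatter), exchanges one halogen for another at a fixed position and lies within the scatter; no measured step moves a group from one place to another on that ring, so nothing directly bears on the change from compound 3 to compound 4. With all three measured compounds sitting at essentially the same number, the expectation for compound 4 is a step of a 1.0-fold lower number from compound 3 to compound 4 (0.01 log units; within the scatter), that is, none beyond the scatter. Compound 4 is therefore estimated at 41000 nM, with a range from 20000 nM to 85000 nM.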

Compound 4, half-maximal inhibitory concentration: 17600 nM
Compound 4: middle estimate off by 2.3-fold (0.37 log units), on the high side, outside the stated range (below it).
By their numbers in this assay, from the lowest: compound 4; then compounds 1, 2 and 3 (each within the scatter of the next).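

In this assay, the group on an oxygen next to a carbonyl group proves sensitive to how its atoms are joined: with the same atoms throughout, the change gives a 2.4-fold lower number from compound 3 to compound 4 (0.37 log units; beyond the scatter). Going by these compounds alone, the halogen exchange alone had given a 1.0-fold higher number from compound 1 to compound 3 (0.01 log units; within the scatter), so this rearrangement is the first change here to move the number beyond the scatter, and the comparison with the fluoro compound, a 2.3-fold lower number from compound 1 to compound 4 (0.36 log units; beyond the scatter), is of similar size. Nothing shown here explains this difference.

Going by these compounds, it remains open whether fluoro or chloro in place of bromo would keep the lower number when the group's atoms are joined as in compound 4. It is also unknown whether a carboxylic acid or an amide in place of the methyl ester would preserve it.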